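The compounds below may be only part of what the source reports. "The series", "measured", "known", "first", "only" and "open" are said of these compounds alone.

In an ADME assay on Vero cells (Chlorocebus sabaeus) for cytotoxicity, read by sulforhodamine B assay, with a stated time of 72 h (on this read-out lower numbers stand for stronger inhibition and higher numbers for weaker inhibition), compound 1 `CN1Cc2ccc(OCCc3ccccc3)cc2[C@@H](O)C1` gives only a limit of the assay, > 50000 nM. Compound 2 `CN1Cc2ccc(OCCC3CCCCC3)cc2[C@@H](O)C1` likewise reaches only a limit in this assay, > 50000 nM. Compound 3 `CN1Cc2ccc(OCCCN3CCNCC3)cc2[C@@H](O)C1` also returns only a limit in this assay, > 100000 nM. The steps among these three, a step that the two limits leave unreadable from compound 1 to compound 2, a step that the two limits leave unreadable from compound 1 to compound 3 and a step that the two limits leave unreadable from compound 2 to compound 3, cannot be read; each end sits at a limit. Compound 3 therefore stands among limits only: the limit of > 100000 nM in this assay, at which 1 of the 3 values shown sits, and (the limit of > 50000 nM in this assay, at which 2 of the 3 values shown sit).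

Compound 4 `CN1Cc2ccc(OCCOc3ccccc3)cc2[C@@H](O)C1` differs from compound 3 by phenoxy in place of (piperazin-1-yl)methyl on a saturated chain carbon, two bonds along the chain from an oxygen on an aromatic ring. Going by the values given here, none of the measured steps can be read on this change, so the three limits are the whole of the evidence. The step expected from compound 3 to compound 4 in this assay is an at least 1.2-fold lower number from compound 3 to compound 4 (0.09 log units; that floor lies within the scatter), which amounts to none beyond the scatter, with compound 4 expected to remain at or past the limit. Compound 4 is accordingly estimated at 80000 nM in this assay, within a range from 40000 nM to 200000 nM, and most probably it too will be reported only as a limit.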

Compound 4, half-maximal inhibitory concentration: > 100000 nM
Compound 4: a limit, no number; the forecaster's own chance of this, stated with the estimate: 85%; middle value at least 1.2-fold (0.09 log units) from the limit.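

With compound 4 also returning only a limit, its steps from compound 1, compound 2 and compound 3 cannot be read. The compounds shown leave open at what concentration, if any, these four would register in this assay, and whether their side chains differ there at all.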